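Swapping the thiazole for a methylimidazole on the sulfonyl

The compounds below may be only part of what the source reports. "The series", "measured", "known", "first", "only" and "open" are said of these compounds alone.

Three compounds share one core, a piperidine joined to a second piperidine that carries a sulfonyl group, and differ only in the ring on the sulfonyl sulfur. In a functional assay on DLD-1 cells (Homo sapiens) for antiproliferative activity, read by CellTiter-Glo, with a stated time of 72 h (a lower number here means a stronger inhibitor, a higher number a weaker inhibitor), compound 1 `CC1CCN(C2CCN(S(=O)(=O)c3cccnc3)CC2)CC1` gives 2400 nM, compound 2 `Cc1ccc(S(=O)(=O)N2CCC(N3CCC(C)CC3)CC2)cc1C` gives 24 nM, and compound 3 `Cc1nc(Cl)sc1S(=O)(=O)N1CCC(N2CCC(C)CC2)CC1` gives 1.6 nM. Compound 3 stands lowest of the three, well separated from both others, as the steps of a 15-fold lower number from compound 2 to compound 3 (1.18 log units; beyond the scatter) and a 1500-fold lower number from compound 1 to compound 3 (3.18 log units; beyond the scatter) show; the step of a 100-fold lower number from compound 1 to compound 2 (2.00 log units; beyond the scatter) lies between them.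

Compound 4 `CC1CCN(C2CCN(S(=O)(=O)c3cn(C)cn3)CC2)CC1` is the next variation: 1-methyl-1H-imidazol-4-yl in place of 2-chloro-4-methyl-1,3-thiazol-5-yl on a sulfonyl sulfur. Among the measured compounds shown here, no measured pair tests this exact change. The closest guide is compound 1, whose pyridin-3-yl is the only other ring among the measured compounds that is neither a substituted phenyl nor the chloro-methyl thiazole, and the step of a 1500-fold lower number from compound 1 to compound 3 (3.18 log units; beyond the scatter) read backwards points to a large rise when that thiazole gives way to a smaller, less substituted ring. A rise beyond the scatter is therefore expected, though its size is uncertain, and compound 4 is expected to show a 310-fold higher number from compound 3 to compound 4 (2.49 log units; beyond the scatter) in this assay. On that basis compound 4 is estimated at 500 nM, within a range from 80 nM to 3000 nM.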

Compound 4, half-maximal inhibitory concentration: > 5000 nM
Compound 4 gave a limit, no number; the forecaster's own chance of this, stated with the estimate: 5%; middle value at least 10-fold (1.00 log units) from the limit.
By their numbers in this assay, from the lowest: compound 3; then compound 2; then compound 1. At a limit, above all of these: compound 4.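

In this assay compound 4 gives a limit of the assay and no number: the limit of > 5000 nM in this assay, at which 1 of the 4 values shown sits. Both steps from the stronger compounds are large, an at least 3100-fold higher number from compound 3 to compound 4 (3.49 log units; beyond the scatter) and an at least 200-fold higher number from compound 2 to compound 4 (2.31 log units; beyond the scatter), and yet the thiazole and the imidazole are each one five-membered aromatic ring with 2 hetero atoms, with the same counts of hydrogen-bond donors and acceptors, so ring size and these counts alone do not separate compound 3 from compound 4. The pyridin-3-yl of compound 1 also turns out not to mark the weak end of the series, as the step of an at least 2.0-fold higher number from compound 1 to compound 4 (0.31 log units; beyond the scatter) shows, although the true size of all three steps stays hidden behind the limit.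

The compounds shown do not tell whether the chlorine, the methyl or the sulfur of the 2-chloro-4-methyl-1,3-thiazol-5-yl group accounts for its low number, as these features always occur together here. Also open, going by these compounds, is how the thiazole would behave with an amine or a methoxy group in place of the chlorine, or how the imidazole would behave with a chlorine added.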